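Linker length and unsaturation in a thiopyrimidine hydroxamate series

The source may hold more compounds than are shown below. What is called first, only, known or untested is meant among the compounds shown, and "the series" means these compounds.

Measured so far in an assay on isolated protein for inhibition of histone deacetylase HD1B (Zea mays); a higher number here means a weaker inhibitor, a lower number a stronger inhibitor:
- compound 1 `O=C(CCCSc1nc(O)cc(CCc2ccccc2)n1)NO`: 170 nM
- compound 2 `O=C(CCCCSc1nc(O)cc(CCc2ccccc2)n1)NO`: 46 nM

Compound 2 holds the lowest number of the two in this assay; its nearest neighbour is compound 1, and the step of a 3.7-fold lower number from compound 1 to compound 2 (0.57 log units; beyond the scatter) arose from a single change, (hydroxycarbamoyl)methyl in place of hydroxycarbamoyl on a saturated chain carbon, three bonds along the chain from a sulfur.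

Compound 3 `O=C(/C=C/Sc1nc(O)cc(CCc2ccccc2)n1)NO` is not yet measured. It differs from compound 2 by 2-(hydroxycarbamoyl)ethenyl in place of 4-(hydroxycarbamoyl)butyl on a sulfur. Within the data shown here, the one measured step that bears on it runs the other way: lengthening the chain from compound 1 to compound 2 lowered the number, and compound 3 carries a still shorter, now unsaturated, link. Among the measured compounds shown here, no measured pair reports the effect of the double bond itself, so that part rests on nothing. Shortening alone argues for a higher number; compound 3 is therefore expected to give a step of an 8.7-fold higher number from compound 2 to compound 3 (0.94 log units; beyond the scatter) and an estimated 400 nM, within 120 nM to 1500 nM.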

Compound 3, half-maximal inhibitory concentration: 96000 nM
For compound 3 the middle estimate is 240-fold (2.38 log units) below the measured one; measured number above the stated range.
By their numbers in this assay, from the lowest: compound 2; then compound 1; then compound 3.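

Notes on the group on the sulfur: in this assay, this position proves far more sensitive than the earlier pair suggested, with 2-(hydroxycarbamoyl)ethenyl giving a 2100-fold higher number from compound 2 to compound 3 (3.32 log units; beyond the scatter) and a 560-fold higher number from compound 1 to compound 3 (2.75 log units; beyond the scatter), both large against the modest 3.7-fold lower number from compound 1 to compound 2 (0.57 log units; beyond the scatter). This change alters chain length and introduces the double bond at once, and these steps do not separate the two contributions. Nothing available accounts for the size of the rise.

The compounds shown leave open whether the saturated 2-(hydroxycarbamoyl)ethyl group would sit close to compound 3 or closer to compound 1, which would isolate the contribution of the double bond. They also leave open whether a longer chain, such as 5-(hydroxycarbamoyl)pentyl, would continue the fall in the number seen on going to compound 2.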